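The compounds below may be only part of what the source reports. "The series", "measured", "known", "first", "only" and "open" are said of these compounds alone.

Three compounds share one core, a dodecyl amide built on a threonine-like unit, and differ only in the group on the amine nitrogen. Compound 1 `CCCCCCCCCCCCNC(=O)[C@@H](NC(=O)c1ccco1)[C@@H](C)O` carries a furan-2-yl carbonyl; in a functional assay on SW-620 cells (Homo sapiens) for cytotoxicity, read by MTT assay, with a stated time of 48 h (on this read-out higher numbers stand for weaker inhibition and lower numbers for stronger inhibition), compound 1 gives 87500 nM. Compound 2 `CCCCCCCCCCCCNC(=O)[C@@H](NC(=O)c1cccs1)[C@@H](C)O` carries a thiophen-2-yl carbonyl, and compound 2 gives 29200 nM. Compound 3 `CCCCCCCCCCCCNC(=O)[C@@H](NS(=O)(=O)c1cccs1)[C@@H](C)O` carries a thiophen-2-yl sulfonyl, and compound 3 gives 27900 nM. Compound 3 has the lowest number of the three, but its gap to compound 2 is within the scatter, so the two cannot be ordered; only compound 1 stands apart. The steps show this: a 3.0-fold lower number from compound 1 to compound 2 (0.48 log units; beyond the scatter), a 3.1-fold lower number from compound 1 to compound 3 (0.50 log units; beyond the scatter), and a 1.0-fold lower number from compound 2 to compound 3 (0.02 log units; within the scatter).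

Compound 4 `CCCCCCCCCCCCCCCCCCNC(=O)[C@@H](NS(=O)(=O)c1cccs1)[C@@H](C)O` keeps everything of compound 3 except the chain: hexyl in place of hydrogen on a saturated chain carbon, ten or more bonds along the chain from an amide-type nitrogen. For the measured compounds named here, no measured step touches the chain; all three steps change the group on the nitrogen. Going by the values given here, there is therefore no direct precedent for this change, and the expectation has to be cautious. Compound 4 is expected to give 20000 nM, within a range from 5000 nM to 80000 nM, which would mean a 1.4-fold lower number from compound 3 to compound 4 (0.14 log units; within the scatter), a step not expected to exceed the scatter with any confidence.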

Compound 4, half-maximal inhibitory concentration: > 200000 nM
Compound 4 gave a limit, no number (the forecaster's own chance of this, stated with the estimate: 10%); middle value at least 10-fold (1.00 log units) away from the limit.
By their numbers in this assay, from the lowest: compounds 3 and 2 (each within the scatter of the next); then compound 1. At a limit, above all of these: compound 4.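

Going by these compounds, compound 4 gives a limit and not a number, so its true value stays unknown: the limit of > 200000 nM in this assay, at which 1 of the 4 values shown sits. Placing hexyl in place of hydrogen on a saturated chain carbon gives an at least 7.1-fold higher number from compound 3 to compound 4 (0.85 log units; beyond the scatter), which means weaker inhibition, and the real step may be larger still, since one end of it is a limit. Compounds 1, 2 and 3 differ only in the group on the nitrogen and so say nothing about the chain; this step shows that the far end of the chain is not a silent place, since a change there, with the thiophen-2-yl sulfonyl group kept, moves the read-out beyond the scatter.

The compounds shown leave open how the read-out changes at chain lengths in the gap between these two, such as a tetradecyl chain, or below the dodecyl chain of compound 3, such as a decyl chain. They also leave open whether the same chain change acts alike with the thiophen-2-yl carbonyl group of compound 2, and whether a chain ending in an amine or a carboxylic acid would behave like the plain one.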